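Swapping the Amide on the Piperazine for a Fluorophenyl Group

The compounds below may be only part of what the source reports. "The series", "measured", "known", "first", "only" and "open" are said of these compounds alone.

The measured compounds:
compound 1, `COC(=O)CC/C(C)=C/Cc1c(OC)c(C)c2c(c1OCC#CCN1CCCc3ccccc31)C(=O)OC2`: 9570 nM
compound 2, `COC(=O)CC/C(C)=C/Cc1c(OC)c(C)c2c(c1OCC#CCN1CCN(C(=O)C3COc4ccccc4O3)CC1)C(=O)OC2`: > 50000 nM
compound 3, `COC(=O)CC/C(C)=C/Cc1c(OC)c(C)c2c(c1OCC#CCN1CCC(Cc3ccccc3)CC1)C(=O)OC2`: 24500 nM

All three share one core and differ only in the amine at the end of the alkyne-bearing chain. In a functional assay on SH-SY5Y cells (Homo sapiens) for inhibition, read by sulforhodamine B assay (a lower number here means a stronger inhibitor, a higher number a weaker inhibitor), compound 1 gives 9570 nM, and compound 3 gives 24500 nM. Compound 2 stands apart: in this assay compound 2 gives > 50000 nM, which is a limit of the assay and not a number; it is the limit of > 50000 nM in this assay, at which 1 of the 3 values shown sits.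

Compound 4, `COC(=O)CC/C(C)=C/Cc1c(OC)c(C)c2c(c1OCC#CCN1CCN(c3ccccc3F)CC1)C(=O)OC2`, is not yet measured. It differs from compound 2 in one place: 2-fluorophenyl in place of (2,3-dihydro-1,4-benzodioxin-2-yl)carbonyl on an amine nitrogen in a ring

Within the data shown here, no step between two measured compounds is available to anchor this change. The two compounds that return numbers in this assay, compound 1 with 9570 nM and compound 3 with 24500 nM, both carry an aromatic group near the ring amine without a carbonyl, as compound 4 does. On that basis compound 4 is expected to give a measurable value, a step of an at least 2.5-fold lower number from compound 2 to compound 4 (0.39 log units; beyond the scatter), beyond the scatter. Compound 4 is estimated at 20000 nM, within a range from 6000 nM to 70000 nM, with a real chance that only a limit is reported again.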

Compound 4, half-maximal inhibitory concentration: 35800 nM
Beside the measured number, compound 4's estimate is 1.8-fold (0.25 log units) below it, and the stated range covers the measured number.
By their numbers in this assay, from the lowest: compound 1; then compounds 3 and 4 (each within the scatter of the next). At a limit, above all of these: compound 2.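

Putting 2-fluorophenyl in place of (2,3-dihydro-1,4-benzodioxin-2-yl)carbonyl on the amine nitrogen in the ring yields a measurable result: in this assay compound 4 gives 35800 nM. Compound 2 stays at a limit of the assay, which is not a number: the limit of > 50000 nM in this assay, at which 1 of the 4 values shown sits. The change therefore reads only as an at least 1.3-fold lower number from compound 2 to compound 4 (0.14 log units; that floor lies within the scatter), so the data show that this position can carry a group that returns a number, but they do not fix the true size of the step.

Going by these compounds, what a plain phenyl group would give on this nitrogen remains open, so the part played by the fluorine cannot be told. A benzoyl group there would also be needed to separate the effect of the carbonyl from that of the rest of the departing group.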